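The source may report more compounds than this note shows. Statements on the series, on what has been measured and on what is new or still open speak of the compounds shown alone.

Measured compounds:
Compound 1, `COc1ccc(-c2cc3ccccc3nc2/C=C/C(=O)c2ccccc2)cc1`: 8560 nM
Compound 2, `COc1ccc(-c2cc3ccccc3nc2/C=C/C(=O)c2ccc(O)cc2)cc1`: 5690 nM

Among the two measured compounds, compound 2 gives the lower number in a functional assay on H184B5F5/M10 cells (Homo sapiens) for antiproliferative activity, read by XTT assay, with a stated time of 72 h (a higher number here means a weaker inhibitor, a lower number a stronger inhibitor), but the single step of a 1.5-fold lower number from compound 1 to compound 2 (0.18 log units; within the scatter) lies within the scatter, so the two values cannot be told apart with confidence. Compound 3, `COc1ccc(C(=O)/C=C/c2nc3ccccc3cc2-c2ccc(OC)cc2)cc1`, differs from compound 2 by methyl in place of hydrogen on an oxygen on an aromatic ring; cut one bond further out, this reads hydroxy to methoxy, or 4-hydroxyphenyl to 4-methoxyphenyl. Within the data shown here, no measured pair shows exactly this change. Among the measured compounds shown here, the only measured step, a 1.5-fold lower number from compound 1 to compound 2 (0.18 log units; within the scatter), touches the same position by adding the hydroxy group, and its size stays within the scatter; this is the nearest guide. Since adding the hydroxy group moved the number so little, capping it with a methyl group is expected to move it little as well, in either direction. Compound 3 is therefore estimated at 7000 nM, within a range of 3000 nM to 16000 nM, which corresponds to an expected step of a 1.2-fold higher number from compound 2 to compound 3 (0.09 log units; within the scatter).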

Compound 3, half-maximal inhibitory concentration: > 10000 nM
Compound 3 gave a limit, no number (the forecaster's own chance of this, stated with the estimate: 10%); middle value at least 1.4-fold (0.15 log units) away from the limit.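

Unlike compounds 1 and 2, which both gave numbers, compound 3 gave only a limit of the assay in this assay: the limit of > 10000 nM in this assay, at which 1 of the 3 values shown sits.

Capping the hydroxy with methyl therefore gives only a floor, an at least 1.7-fold higher number from compound 2 to compound 3 (0.24 log units; that floor lies within the scatter), so this change may matter more than the first step suggested, but the result does not prove it. Methoxy in place of hydrogen on the aromatic carbon likewise gives only a floor, an at least 1.1-fold higher number from compound 1 to compound 3 (0.06 log units; that floor lies within the scatter), so no firm order among the three compounds can be read.

The compounds shown leave open how far past its limit compound 3 truly lies. They also leave open how an amine or a carboxylic acid in this place, or a longer chain on the oxygen, would read in this assay.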